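Adding a Methyl to a Series Without Measurable Inhibition

The source may report more compounds than this note shows. Statements on the series, on what has been measured and on what is new or still open speak of the compounds shown alone.

Compound 1 `CCC(C)C1NC(=O)N(C2CCCCC2)C1=O` in a functional assay on MOLT-4 cells (Homo sapiens) for inhibition (on this read-out lower numbers stand for stronger inhibition and higher numbers for weaker inhibition), gives only a limit, > 200000 nM.
Compound 2 `CC(C)C(NC(=O)n1nnc2ccccc21)C(=O)NC1CCCC1` in this assay gives only a limit, > 200000 nM.
Compound 3 `CC(C)C1NC(=O)N(C2CCCCC2)C1=O` in this assay gives only a limit, > 200000 nM.

From compound 3 to compound 1 the change is methyl in place of hydrogen on a saturated chain carbon, two bonds along the chain from a saturated ring carbon. The step that the two limits leave unreadable from compound 3 to compound 1 is unreadable because both values sit at the limit of > 200000 nM in this assay, at which 3 of the 3 values shown sit. Compound 4 `CCC(C)C(NC(=O)n1nnc2ccccc21)C(=O)NC1CCCC1` differs from compound 2 by methyl in place of hydrogen on a saturated chain carbon, three bonds along the chain from an amide-type nitrogen and a carbonyl carbon; this is the same kind of change, but the place differs: two bonds along the chain from a saturated ring carbon in compound 3, three bonds along the chain from an amide-type nitrogen and a carbonyl carbon in compound 2. The difference between the cores of compound 2 and compound 3 is not broken down here. Since the earlier step could not be read, the step that the limit leaves unreadable from compound 2 to compound 4 is expected to be small and most likely again to end at the limit. Compound 4 is estimated at 250000 nM, between 50000 nM and 1000000 nM.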

Compound 4, half-maximal inhibitory concentration: 94000 nM
For compound 4 the middle estimate is 2.7-fold (0.42 log units) above the measured one; measured number inside the range.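

On the core of compound 2, the change from isopropyl to sec-butyl gives in this assay an at least 2.1-fold lower number from compound 2 to compound 4 (0.32 log units; beyond the scatter), and compound 4 is the only compound shown with a readable value. The same kind of change on the core of compound 3 cannot be read, and the size of the step on the core of compound 2 is only a bound, with the values here resting on one limit: the limit of > 200000 nM in this assay, at which 3 of the 4 values shown sit. Whether the methyl carries from one core to the other is therefore not shown, as the place of the change also differs between them.

On these data alone, it remains open whether a longer chain in place of sec-butyl would lower the number further in this assay. As far as these compounds go, the effect of an amine or a carboxylic acid on that chain is also open.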